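Bromo for phenyl on the shared core: compound 4

The compounds below may be only part of what the source reports. "The series", "measured", "known", "first", "only" and "open" are said of these compounds alone.

Going by the values given here, compound 2 `Cc1c(-c2ccccc2)cn(Cc2ccc(F)cc2)c(=O)c1C(=O)NC1CCCCCC1` is the only member of this set with a number: in an ADME assay on cells for inhibition of Fatty-acid amide hydrolase 1 (Homo sapiens), with stated times of 30 min and 15 min (on this read-out lower numbers stand for stronger inhibition and higher numbers for weaker inhibition), compound 2 gives 70 nM. Compound 3 `O=C(NC1CCCCCC1)c1c(-c2ccccc2)c(-c2ccccc2)cn(Cc2ccc(F)cc2)c1=O` differs by methyl in place of phenyl on an aromatic carbon; in this assay compound 3 reaches only the limit > 10000 nM, not a number. Hence an at least 140-fold higher number from compound 2 to compound 3 (2.15 log units; beyond the scatter), a step read only against (the limit of > 10000 nM in this assay, at which 2 of the 3 values shown sit). Compound 1 `O=C(NC1CCCCCC1)c1c(-c2ccccc2)c(Br)cn(Cc2ccc(F)cc2)c1=O` carries bromo in place of phenyl on an aromatic carbon; in this assay compound 1 likewise gives the limit > 10000 nM. Thus a step that the two limits leave unreadable from compound 3 to compound 1. Compound 4 `Cc1c(Br)cn(Cc2ccc(F)cc2)c(=O)c1C(=O)NC1CCCCCC1`, not yet measured, carries bromo in place of phenyl on an aromatic carbon, the same kind of change as that from compound 3 to compound 1, though there the place is ortho to a phenyl group and here ortho to a methyl group. With the earlier step unreadable, the size of a 4.3-fold higher number from compound 2 to compound 4 (0.63 log units; beyond the scatter) is expected to be modest. Compound 4 is estimated at 300 nM, between 50 nM and 5000 nM.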

Compound 4, half-maximal inhibitory concentration: 2300 nM
Estimate against measurement, compound 4: 7.7-fold (0.88 log units) below; low and high end bracket the measured number.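

Bromo in place of phenyl gives a large step on the core of compound 2 (a 33-fold higher number from compound 2 to compound 4 (1.52 log units; beyond the scatter)), and methyl in place of phenyl gives a lower number on the bromo-bearing core (an at least 4.3-fold lower number from compound 1 to compound 4 (0.63 log units; beyond the scatter)). Phenyl in place of methyl therefore raises the number in this assay on both cores, so the direction carries from one core to the other: the same change on two cores in this assay, an at least 140-fold higher number (2.15 log units; beyond the scatter) from compound 2 to compound 3 and an at least 4.3-fold higher number (0.63 log units; beyond the scatter) from compound 4 to compound 1; the limit leaves it open whether they differ. The size does not carry in any readable way, and the step from compound 3 to compound 1 cannot be read, since both compounds sit at a limit: the limit of > 10000 nM in this assay, at which 2 of the 4 values shown sit.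

The compounds shown leave open how chloro, methoxy or a plain hydrogen would read in the place held by bromo in compound 4. They also leave open whether an amine or a carboxylic acid there would be tolerated.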